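The source may hold more compounds than are shown below. What is called first, only, known or untested is meant among the compounds shown, and "the series" means these compounds.

Measured compounds:
compound 1 `COc1ccccc1-c1nnc(-c2ccc(C(=O)N/N=C/c3ccc([N+](=O)[O-])cc3)cc2)o1` gives 203000 nM
compound 2 `COc1ccccc1-c1nnc(-c2ccc(C(=O)N/N=C/c3ccncc3)cc2)o1` gives 173000 nM
compound 3 `COc1ccccc1-c1nnc(-c2ccc(C(=O)N/N=C/c3cccnc3)cc2)o1` gives 167000 nM

All three share one core and differ only in the aromatic group on the carbon with a double bond to nitrogen. In an ADME assay on THP-1 cells (Homo sapiens) for cytotoxicity (a higher number here means a weaker inhibitor, a lower number a stronger inhibitor), compound 3 shows the lowest of the three numbers, but its gaps to the other two are within the scatter: a 1.0-fold lower number from compound 2 to compound 3 (0.02 log units; within the scatter) and a 1.2-fold lower number from compound 1 to compound 3 (0.08 log units; within the scatter). The remaining measured step, a 1.2-fold lower number from compound 1 to compound 2 (0.07 log units; within the scatter), is likewise within the scatter. So the three measured compounds cannot be ordered in this assay.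

Compound 4 `COc1ccccc1-c1nnc(-c2ccc(C(=O)N/N=C/c3ccccn3)cc2)o1` is not yet measured. It differs from compound 3 by pyridin-2-yl in place of pyridin-3-yl on a carbon with a double bond to nitrogen. Among the measured compounds shown here, the steps that bear on it are those exchanging one aromatic group for another at the same position, and each of them stayed within the scatter, including the pyridine-to-pyridine step a 1.0-fold lower number from compound 2 to compound 3 (0.02 log units; within the scatter). Moving the ring nitrogen once more is therefore expected to give no step beyond the scatter in this assay: the expected step is a 1.0-fold higher number from compound 3 to compound 4 (0.02 log units; within the scatter), with no preferred direction.

For compound 4 the estimated value in this assay is 175000 nM, with a range from 100000 nM to 300000 nM.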

Compound 4, half-maximal inhibitory concentration: 67000 nM
Beside the measured number, compound 4's estimate is 2.6-fold (0.42 log units) above it, outside the stated range (below it).
By their numbers in this assay, from the lowest: compound 4; then compounds 3, 2 and 1 (each within the scatter of the next).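

At the position on a carbon with a double bond to nitrogen, the series is no longer flat in this assay: pyridin-2-yl stands apart from the other three groups, with a 2.5-fold lower number from compound 3 to compound 4 (0.40 log units; beyond the scatter) and a 2.6-fold lower number from compound 2 to compound 4 (0.41 log units; beyond the scatter) for the two pyridine isomers and a 3.0-fold lower number from compound 1 to compound 4 (0.48 log units; beyond the scatter) for 4-nitrophenyl, all modest in size. Compound 4 is therefore the strongest inhibitor of the four in this cytotoxicity read-out, and the position proves sensitive to the choice of pyridine isomer, although the pyridin-3-yl and pyridin-4-yl compounds remain within the scatter of each other; since pyridin-3-yl and pyridin-2-yl have the same heavy atoms and the same donor and acceptor counts, those counts do not separate compound 3 from compound 4. No supporting measurement is available to explain why this one isomer differs.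

Open, as far as these compounds go, is whether a plain phenyl or a pyrimidin-2-yl group on this carbon would share the lower number of compound 4 or group with compounds 1, 2 and 3, and whether an amine or a carboxylic acid on the pyridin-2-yl ring would shift it further. Also open, from the compounds shown here alone, is whether the same step appears with a methyl group in place of the methoxy group on the shared core.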